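Swapping the saturated ring on the shared core

A few compounds are considered here, and "the series" means these few. Any claim that something is new, unique, unknown or untested is made for them only; others in the source may bear on it.

The three measured compounds share one core and differ at two places. In an assay on HEK293 cells for inhibition of acid ceramidase (Homo sapiens), read by fluorescence, with stated times of 10 min and 3 h (a lower number here means a stronger inhibitor, a higher number a weaker inhibitor), compound 1 `CC(C)CNC(=O)n1c(=O)oc2cc(C3CCN(C)CC3)ccc21` gives 166 nM and compound 2 `CC(C)CNC(=O)n1c(=O)oc2c(C3CCN(C)CC3)cccc21` gives 535 nM. Compound 3 `O=C(NCCCCc1ccccc1)n1c(=O)oc2cc(C3CCOCC3)ccc21` gives 68 nM in this assay, the lowest of the three numbers, set apart from compound 1 and compound 2 by gaps beyond the scatter. Compound 4 `CCN1CCC(c2ccc3c(c2)oc(=O)n3C(=O)NCCCCc2ccccc2)CC1` keeps the chain of compound 3 and changes only the saturated ring: 1-ethylpiperidin-4-yl in place of oxan-4-yl on an aromatic carbon. Within the data shown here, no measured pair shows this ring exchange alone, so the step is expected to be modest, and compound 4 is estimated to change this assay by a 1.3-fold higher number from compound 3 to compound 4 (0.12 log units; within the scatter). Compound 4 is expected to give about 90 nM, within 35 nM to 250 nM.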

Compound 4, half-maximal inhibitory concentration: 92 nM
Beside the measured number, compound 4's estimate is 1.0-fold (0.01 log units) below it; measured number inside the range.
By their numbers in this assay, from the lowest: compounds 3, 4 and 1 (each within the scatter of the next, the first and the last beyond it); then compound 2.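

With the chain of compound 3 held in place, 1-ethylpiperidin-4-yl in place of oxan-4-yl on this aromatic carbon gives a 1.4-fold higher number from compound 3 to compound 4 (0.13 log units; within the scatter) in this assay and so leaves the reading within the scatter. This is the first single exchange of the saturated ring shown at this place, and the two rings cannot be told apart by this measure. Nothing measured here bears on why they read alike.

Still open, going by these compounds, is how a piperidine with no group on its nitrogen, or an oxan-4-yl ring carrying a carboxylic acid, would read on this carbon. Also open, on these data alone, is whether the same exchange holds with the chain of compound 1.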